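Swapping pyrrolidine for morpholine on a chromone dithiocarbamate

The compounds below may be only part of what the source reports. "The series", "measured", "known", "first", "only" and "open" are said of these compounds alone.

The measured compounds:
compound 1, `CCOC(=O)c1cc(=O)c2cc(CSC(=S)N(C)c3ccccc3)ccc2o1`, > 25000 nM in a functional assay on LM7 cells (Homo sapiens) for antiproliferative activity, read by MTT assay, with a stated time of 72 h; a lower number here means a stronger inhibitor, a higher number a weaker inhibitor;
compound 2, `O=c1c(Cl)c(CSC(=S)N2CCCC2)oc2ccccc12`, 1900 nM;
compound 3, `CCOC(=O)c1cc(=O)c2cc(CSC(=S)N3CCCC3)ccc2o1`, 18000 nM.

Compound 1 is reported only as a limit of this assay, (the limit of > 25000 nM in this assay, at which 1 of the 3 values shown sits), and not as a number. Among the two numbers shown, compound 3 stands highest; compound 2, its nearest neighbour, shows a lower number, a gap beyond the scatter. Among the measured compounds shown here, compound 2 differs from compound 3 in more than one place, so the data give no single step between them.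

Compound 4, `CCOC(=O)c1cc(=O)c2cc(CSC(=S)N3CCOCC3)ccc2o1`, has not yet been measured. It differs from compound 3 in one place: morpholin-4-yl in place of pyrrolidin-1-yl on a thiocarbonyl carbon.

For the measured compounds named here, only one measured step touches this position on the thiocarbonyl carbon: an at least 1.3-fold lower number from compound 1 to compound 3 (0.14 log units; that floor lies within the scatter). That step lies within the scatter, and it concerns a different pair of groups, so it bears on the new change only loosely. Nothing in the data points to a large shift from the ring exchange. Compound 4 is therefore expected to stay close to compound 3, with a step of a 1.2-fold higher number from compound 3 to compound 4 (0.09 log units; within the scatter) expected, and a real chance that only a limit is reported. Compound 4 is estimated at 22000 nM, within 8000 nM to 60000 nM.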

Compound 4, half-maximal inhibitory concentration: > 25000 nM
Compound 4: only a limit was reported; the forecaster's own chance of this, stated with the estimate: 40%; middle value at least 1.1-fold (0.05 log units) away from the limit.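

Placing morpholin-4-yl in place of pyrrolidin-1-yl on the thiocarbonyl carbon gives an at least 1.3-fold higher number from compound 3 to compound 4 (0.14 log units; that floor lies within the scatter), so the exchange brings no gain here, yet the printed floor does not establish a real loss either. Of the three compounds that share this core, only compound 3, with pyrrolidin-1-yl, now gives a number, while the step between the two limited compounds, compound 1 and compound 4, cannot be read. Compound 4 is reported, like compound 1, only as a limit in this assay: the limit of > 25000 nM in this assay, at which 2 of the 4 values shown sit.

As far as these compounds go, how far compound 4 actually lies from compound 3 stays open, and so does the true size of this ring exchange. Also open, from the compounds shown here alone, is whether the loss of a number follows the larger ring or its oxygen, which piperidin-1-yl on the same thiocarbonyl carbon would separate, and whether morpholin-4-yl would behave in the same way on the core of compound 2, which carries the chlorine and lacks the ethyl ester.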